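This account rests on a few compounds, and the source may have more. Where it says the series, first, only, none or still open, it means among the compounds named here.

Of the compounds shown here, three that share one core have been tested in an in vitro functional assay on cells for agonist activity at Bombesin receptor subtype-3 (Homo sapiens), read by luminescence and calcium flux; a higher number here means that more compound is needed for the effect, a lower number that less compound is needed. Compound 1 `O=C(O)c1ccccc1-c1ccc(CCc2ncc(Cc3ccccc3F)[nH]2)cc1` carries a 2-fluorophenyl on a saturated chain carbon bound to an aromatic carbon and gives 177 nM. Compound 2 `N#Cc1ccc(Cc2cnc(CCc3ccc(-c4ccccc4C(=O)O)cc3)[nH]2)cc1` carries a 4-cyanophenyl at that place and gives 5890 nM. Compound 3 `O=C(O)c1ccccc1-c1ccc(CCc2ncc(Cc3ccc(F)cc3)[nH]2)cc1` carries a 4-fluorophenyl there and gives 1600 nM, which puts it second highest of the three numbers, with compound 2 nearest and compound 1 furthest. The step from compound 1 to compound 3 amounts to a 9.0-fold higher number from compound 1 to compound 3 (0.96 log units; beyond the scatter), and the step from compound 2 to compound 3 to a 3.7-fold lower number from compound 2 to compound 3 (0.57 log units; beyond the scatter).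

Compound 4 `O=C(O)c1ccccc1-c1ccc(CCc2ncc(Cc3cccc(Cl)c3)[nH]2)cc1` has not yet been measured. It differs from compound 3 in one place: 3-chlorophenyl in place of 4-fluorophenyl on a saturated chain carbon bound to an aromatic carbon. Going by the values given here, no measured step swaps fluoro for chloro, and none involves a 3-chlorophenyl group, so the guidance is indirect. Moving the fluorine on the ring, as in a 9.0-fold higher number from compound 1 to compound 3 (0.96 log units; beyond the scatter), shifted the number beyond the scatter, whereas exchanging one small group for another, as in a 3.7-fold lower number from compound 2 to compound 3 (0.57 log units; beyond the scatter), gave a smaller shift. A modest change in either direction, not far beyond the scatter, is therefore the expectation. Compound 4 is estimated at 1000 nM, within a range from 250 nM to 4000 nM. This estimate corresponds to an expected step of a 1.6-fold lower number from compound 3 to compound 4 (0.20 log units; within the scatter).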

Compound 4, half-maximal effective concentration: 825 nM
The estimate for compound 4 lay 1.2-fold (0.08 log units) above the measured number, and the stated range covers the measured number.
By their numbers in this assay, from the lowest: compound 1; then compounds 4 and 3 (each within the scatter of the next); then compound 2.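

On a saturated chain carbon bound to an aromatic carbon, 3-chlorophenyl reads much like 4-fluorophenyl (a 1.9-fold lower number from compound 3 to compound 4 (0.29 log units; within the scatter)), so this first chlorine-bearing group cannot be told apart from compound 3. Its number is clearly lower than that of the 4-cyanophenyl compound (a 7.1-fold lower number from compound 2 to compound 4 (0.85 log units; beyond the scatter)) but clearly higher than that of the 2-fluorophenyl compound (a 4.7-fold higher number from compound 1 to compound 4 (0.67 log units; beyond the scatter)), which leaves compound 1 with the lowest number of the four. No available measurement gives a reason for these gaps.

Each ring so far carries either one halogen or one nitrile, and the two halogens appear on different ring carbons. The choice of halogen and its place on the ring remain tangled: 2-chlorophenyl and 3-fluorophenyl are the groups that could pull them apart. Also open, going by these compounds, is how a phenyl carrying an amine or a methoxy group, or a longer chain between this phenyl and the shared core, would read in this assay when set against compound 1.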